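A few compounds are considered here, and "the series" means these few. Any claim that something is new, unique, unknown or untested is made for them only; others in the source may bear on it.

Series in a functional assay on Caco-2 cells (Homo sapiens) for cytotoxicity, read by colony formation; on this read-out higher numbers stand for weaker inhibition and lower numbers for stronger inhibition:
- compound 1 `COC(=O)C1=CO[C@@H](O[C@@H]2O[C@H](COC(c3ccccc3)(c3ccccc3)c3ccccc3)[C@@H](O)[C@H](O)[C@H]2O)[C@@H]2[C@@H](C)[C@@H](O)C[C@H]12`: 2.54 ug/mL
- compound 2 `COC(=O)C1=CO[C@@H](O[C@@H]2O[C@H](COC(c3ccccc3)(c3ccccc3)c3ccccc3)[C@@H](OC(=O)O)[C@H](OC(C)=O)[C@H]2OC(C)=O)[C@@H]2[C@@H](C)[C@@H](OC(C)=O)C[C@H]12`: 1.28 ug/mL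
- compound 3 `CCC(=O)OC[C@H]1O[C@@H](O[C@@H]2OC=C(C(=O)OC)[C@H]3C[C@H](OC(C)=O)[C@H](C)[C@@H]23)[C@H](OC(C)=O)[C@@H](OC(C)=O)[C@@H]1OC(C)=O`: 4.88 ug/mL

Compound 3 stands at the upper end of these three numbers. It is level with compound 1 within the scatter and separated from compound 2 by more than the scatter.

Compound 4 `COC(=O)C1=CO[C@@H](O[C@@H]2O[C@H](COC(=O)C=C(C)C)[C@@H](OC(C)=O)[C@H](OC(C)=O)[C@H]2OC(C)=O)[C@@H]2[C@@H](C)[C@@H](OC(C)=O)C[C@H]12` is the next analogue to follow from compound 3. The change is 2-methylprop-1-en-1-yl in place of ethyl on a carbonyl carbon. For the measured compounds named here, no pair of measured compounds differs in one place only, so the series offers no direct measure of this change.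

No step beyond the scatter is expected in this assay. This expectation rests on compound 3 at 4.88 ug/mL, with a small allowance towards compound 1 at 2.54 ug/mL. The estimated step is a 1.4-fold lower number from compound 3 to compound 4 (0.14 log units; within the scatter), and it is expected to stay within the scatter. For compound 4 the estimated value is 3.5 ug/mL, with an expected range of 1.3 ug/mL to 9 ug/mL.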

Compound 4, half-maximal inhibitory concentration: 6.2 ug/mL
For compound 4 the middle estimate is 1.8-fold (0.25 log units) below the measured one, within the range that was stated.
By their numbers in this assay, from the lowest: compounds 2, 1, 3 and 4 (each within the scatter of the next, the first and the last beyond it).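

For the compounds shown here, replacing ethyl with 2-methylprop-1-en-1-yl on a carbonyl carbon gives the first comparison in this assay between compounds that differ in one place: a 1.3-fold higher number from compound 3 to compound 4 (0.10 log units; within the scatter). The two compounds therefore read as level, so in this one pair the larger group, with its double bond outside aromatic rings, brings no step beyond the scatter at this position. No measurement on hand accounts for this level result.

On these data alone, whether a longer saturated chain, a phenyl ring or an aminomethyl group on the same carbonyl carbon would also stay within the scatter remains open. Compound 1 and compound 2 differ from compound 3 and compound 4 in more than one place, so the effect of the other changes across the series cannot be read.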